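The source may report more compounds than this note shows. Statements on the series, on what has been measured and on what is new or still open speak of the compounds shown alone.

Of the compounds shown here, two from this study have numbers so far. Compound 1 `C=C1C(=O)O[C@@H]2C/C(C)=C/CC/C(C)=C/CC[C@]3(C)O[C@H]3C[C@@H]12` is a fused three-ring lactone; in a functional assay on HT-29 cells (Homo sapiens) for cytotoxicity (a lower number here means that less compound is needed, a higher number that more compound is needed for the effect), compound 1 gives 7.55 ug/mL. Compound 2 `C=C1C(=O)O[C@@H]2[C@H]1[C@H](OC(C)=O)C/C(C)=C/C[C@H](OC(C)=O)/C(C)=C/C[C@@H](OC(C)=O)[C@]1(C)O[C@@H]21` carries three acetoxy groups on a related core, and in this assay compound 2 gives 4.97 ug/mL. Compound 1 has the highest of the two numbers, but its nearest neighbour is compound 2, and the gap between them lies within the usual scatter of repeated measurements, so the two cannot be told apart on these numbers.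

Compound 3 `C=C1C(=O)O[C@H]2[C@H]1C[C@@H]1O[C@@]1(C)CC/C=C(\C)CC/C=C(\C)[C@@H]2OC(C)=O` has not yet been measured. It differs from compound 1 in one place: acetoxy in place of hydrogen on a saturated ring carbon

Compound 2, which carries three acetoxy groups, sits within the scatter of compound 1, so a single added acetoxy group gives little reason to expect a large move. The step from compound 1 to compound 3 in this assay is expected to stay within the scatter, if anything toward a slightly lower number, as a 1.3-fold lower number from compound 1 to compound 3 (0.10 log units; within the scatter). Compound 3 is therefore estimated at 6 ug/mL, with a plausible range from 2.5 ug/mL to 15 ug/mL.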

Compound 3, concentration for half-maximal effect: 5.67 ug/mL
Beside the measured number, compound 3's estimate is 1.1-fold (0.02 log units) above it; the measured number falls inside the stated range.
By their numbers in this assay, from the lowest: compounds 2, 3 and 1 (each within the scatter of the next).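

Compound 2 differs from compound 1 in more than one place, so it could not show what any single acetoxy group does. The new pair isolates one such change: acetoxy in place of hydrogen on a saturated ring carbon of the 14-membered ring gives a 1.3-fold lower number from compound 1 to compound 3 (0.12 log units; within the scatter) in this assay, a step that lies within the scatter. This carbon can therefore carry an acetoxy group without a measurable shift in this cytotoxicity read-out, although nothing here explains that result.

Among these compounds, this single step covers only one group at one carbon, so it remains open whether a hydroxyl group, an amine or a longer chain at the same carbon would also leave the number within the scatter of compound 1. Among the compounds shown here, it also leaves open what an acetoxy group would do alone on any other carbon of the core of compound 1, since no single-place step reads any other position.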